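Ethoxy to aminoamino on a carbamate-type carbon

The compounds below may be only part of what the source reports. "The series", "measured", "known", "first", "only" and "open" are said of these compounds alone.

Of the compounds shown here, three have been measured in a functional assay on MIA PaCa-2 cells (Homo sapiens) for inhibition, read by MTT assay, with a stated time of 4 days; on this read-out higher numbers stand for weaker inhibition and lower numbers for stronger inhibition. Compound 1 `CCOC(=O)NC(c1ccccc1)c1ccc(Cl)cc1` gives 142000 nM; compound 2 `O=C(NC(c1ccccc1)c1ccc(Cl)cc1)NC(c1ccccc1)c1ccc(Cl)cc1` gives 97000 nM; compound 3 `COc1cc(NC(C)CCCNC(=O)NNC(=O)NCCCCCO)c2ncccc2c1` gives 168000 nM. Compound 1 sits among three numbers that all lie within the usual scatter of one another, so nothing separates it from compound 2 or compound 3.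

Compound 4 `NNC(=O)NC(c1ccccc1)c1ccc(Cl)cc1` differs from compound 1 in one place: aminoamino in place of ethoxy on a carbonyl carbon. No pair of measured compounds shows what such an exchange does, and the three numbers at hand give no reason to expect a shift beyond the scatter. Compound 4 is therefore expected to land close to compound 1, a step of a 1.1-fold higher number from compound 1 to compound 4 (0.02 log units; within the scatter), with an estimate of 150000 nM in a range from 60000 nM to 400000 nM.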

Compound 4, half-maximal inhibitory concentration: 178000 nM
Estimate against measurement, compound 4: 1.2-fold (0.07 log units) below; measured number inside the range.
By their numbers in this assay, from the lowest: compounds 2, 1, 3 and 4 (each within the scatter of the next).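

In this assay, aminoamino in place of ethoxy on a carbonyl carbon gives a 1.3-fold higher number from compound 1 to compound 4 (0.10 log units; within the scatter), so this first step read at this position stays within the scatter. On this core, then, the exchange of ethoxy for aminoamino, with its hydrogen-bond donors, does not separate the two compounds. No measurement of any property bears on this result. As far as these compounds go, whether a methylamino or a benzyloxy group on this carbonyl carbon would give a step beyond the scatter stays open. So does whether a carboxylic acid elsewhere on the shared core would.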